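A few compounds are considered here, and "the series" means these few. Any claim that something is new, unique, unknown or untested is made for them only; others in the source may bear on it.

The compounds share a phenyl-terminated seven-carbon ketone chain capped by a five-membered heteroaromatic ring. Compound 1 `O=C(CCCCCCc1ccccc1)c1nnn[nH]1` carries a tetrazole; in an assay on HEK-293T cells for inhibition of diacylglycerol lipase-alpha (Homo sapiens), read by colorimetric assay (on this read-out higher numbers stand for weaker inhibition and lower numbers for stronger inhibition), compound 1 reaches only the limit > 10000 nM; > 10000 nM (2 entries) in both of its entries. Compound 2 `O=Cc1coc(C(=O)CCCCCCc2ccccc2)n1` bears an oxazole carrying a formyl group, and in this assay compound 2 gives 1510 nM. Compound 3 `COc1cnc(C(=O)CCCCCCc2ccccc2)o1` carries a methoxy group on that oxazole in place of the formyl group. In this assay compound 3 gives only the limit > 10000 nM, with a second entry likewise without a number. Within the data shown here, the change an at least 6.6-fold higher number from compound 2 to compound 3 (0.82 log units; beyond the scatter) is the only measured step here, and it ends at the limit of > 10000 nM in this assay, at which 1 of the 3 values shown sits, so its true size is unknown. Compound 4 `COc1ccc(-c2cnc(C(=O)CCCCCCc3ccccc3)o2)nc1` is obtained from compound 3 by the change (5-methoxypyridin-2-yl in place of methoxy on an aromatic carbon). No measured step concerns a group of this kind, so there is no precedent among these compounds for its size or direction. Compound 3 stands at the limit, so any single number for compound 4 would already be a lower one. Compound 4 is therefore estimated at 200 nM, between 20 nM and 3000 nM, meaning an expected step of an at least 50-fold lower number from compound 3 to compound 4 (1.69 log units; beyond the scatter).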

Compound 4, half-maximal inhibitory concentration: > 10000 nM
Compound 4: a limit, no number (the forecaster's own chance of this, stated with the estimate: 15%); middle value at least 50-fold (1.69 log units) from the limit.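

In this assay compound 4 gives > 10000 nM as a limit and not a number. Among these compounds, compound 3 also stands only at a limit, so no step from compound 3 to compound 4 can be read. The compounds shown leave open whether 5-methoxypyridin-2-yl in place of methoxy changes inhibition at all, and in which direction.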